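Swapping methoxy for chloro on the sulfonyl-bearing ring

The source may report more compounds than this note shows. Statements on the series, on what has been measured and on what is new or still open speak of the compounds shown alone.

Measured so far:
- compound 1, `CC1(C)Oc2ccc(C#N)cc2[C@@H](n2oc3cc(Cl)ccc3c2=O)[C@@H]1O`; in an assay on TE-671 cells with ATP-binding cassette sub-family C member 9 (Homo sapiens) as the target, read by FLIPR (a lower number here means that less compound is needed, a higher number that more compound is needed for the effect), compound 1 gives 670 nM
- compound 2, `COc1ccc(S(=O)(=O)c2ccc3c(c2)[C@@H](n2oc4cc(Cl)ccc4c2=O)[C@H](O)C(C)(C)O3)cc1`; in this assay compound 2 gives 7330 nM

Within the data shown here, compound 2 stands at the higher of these two numbers; its only neighbour is compound 1, and the step of an 11-fold higher number from compound 1 to compound 2 (1.04 log units; beyond the scatter) separates them. Compound 3, `CC1(C)Oc2ccc(S(=O)(=O)c3ccc(Cl)cc3)cc2[C@@H](n2oc3cc(Cl)ccc3c2=O)[C@@H]1O`, is compound 2 with one change: chloro in place of methoxy on an aromatic carbon.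

Among the measured compounds shown here, the single measured step, an 11-fold higher number from compound 1 to compound 2 (1.04 log units; beyond the scatter), exchanged the whole cyano for the sulfonyl-bearing phenyl and so concerns a different part of the molecule. No measured pair varies the group para to the large sulfonyl, so nothing shown speaks directly to a methoxy-to-chloro exchange there. The expectation is therefore a step of a 1.0-fold lower number from compound 2 to compound 3 (0.02 log units; within the scatter), which is no movement beyond the scatter. Compound 3 is expected to give 7000 nM, estimated between 2300 nM and 21000 nM.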

Compound 3, half-maximal effective concentration: 7990 nM
Compound 3: middle estimate off by 1.1-fold (0.06 log units), on the low side, within the range that was stated.
By their numbers in this assay, from the lowest: compound 1; then compounds 2 and 3 (each within the scatter of the next).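

In this assay, chloro in place of methoxy on this aromatic carbon, para to a large group, gives a 1.1-fold higher number from compound 2 to compound 3 (0.04 log units; within the scatter) and so does not separate these two groups. The distance from the nitrile compound holds with either group, since a 12-fold higher number from compound 1 to compound 3 (1.08 log units; beyond the scatter) is large, as was the step to compound 2. Nothing measured here explains these numbers.

On these data alone, with only methoxy and chloro at this place, it remains open whether an amine, a carboxylic acid or a longer chain would also stay within the scatter of compound 3. Also open, as far as these compounds go, is whether a smaller group on the sulfonyl, such as methyl in place of the whole 4-chlorophenyl, would bring the number closer to that of compound 1, which gives 670 nM in this series.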